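The source may report more compounds than this note shows. Statements on the series, on what has been measured and on what is new or still open speak of the compounds shown alone.

In a functional assay on WI-38 cells (Homo sapiens) for inhibition (a higher number here means a weaker inhibitor, a lower number a stronger inhibitor), compound 1 `CC(O)n1cnc2c(N)nc(I)nc21` gives > 500000 nM, which is a limit of the assay rather than a number. Compound 2 `Nc1nc(I)nc2c1ncn2OCCO` carries 2-hydroxyethoxy in place of 1-hydroxyethyl on an aromatic nitrogen and in this assay also reaches only the limit > 500000 nM. The step that the two limits leave unreadable from compound 1 to compound 2 therefore cannot be read because of the limit of > 500000 nM in this assay, at which 3 of the 3 values shown sit. Compound 3 `CC(O)n1cnc2c(S)nc(F)nc21` differs from compound 1 in more than one place, and the difference between the two cores is not broken down here. In this assay compound 3 likewise stops at the limit > 500000 nM. Compound 4 `OCCOn1cnc2c(S)nc(F)nc21` carries the same change on the core of compound 3, (2-hydroxyethoxy in place of 1-hydroxyethyl on an aromatic nitrogen). The expected step of a number no higher from compound 3 to compound 4 (the limit leaves the size open) rests on no readable size, only on the three limits. Compound 4 is therefore expected near 500000 nM, between 100000 nM and 1000000 nM, most likely again as a limit.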

Compound 4, half-maximal inhibitory concentration: > 500000 nM
Compound 4 ended at the assay's limit; the forecaster's own chance of this, stated with the estimate: 90%; the middle value sits exactly at the limit.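

No new step can be read from compound 3 to compound 4, because compound 4 also stops at a limit: the limit of > 500000 nM in this assay, at which 4 of the 4 values shown sit. The compounds shown leave open how large the change from 1-hydroxyethyl to 2-hydroxyethoxy really is, and whether any of them inhibits at a readable concentration.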